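From chloro to trifluoromethyl on compound 1

This account rests on a few compounds, and the source may have more. Where it says the series, first, only, none or still open, it means among the compounds named here.

- Compound 1 `COc1cc(-c2ccnc3cc(-c4ccc(Cl)cc4)nn23)cc(OC)c1OC`: 4090 nM
- Compound 2 `Cn1ccc2cc(-c3cc4nccc(-c5ccc(F)cc5)n4n3)ccc21`: 4780 nM

These two values come from a functional assay on B16-F0 cells (Mus musculus) for inhibition, read by CCK-8 assay, with a stated time of 48 h; a higher number here means a weaker inhibitor, a lower number a stronger inhibitor. Compound 1 and compound 2 lie within the usual scatter of each other, so compound 1 has no clear lead. Compound 3 `COc1cc(-c2ccnc3cc(-c4ccc(C(F)(F)F)cc4)nn23)cc(OC)c1OC` keeps the core of compound 1 but has trifluoromethyl in place of chloro on an aromatic carbon. Among the compounds with values here, no measured pair shows what this swap does, so no step beyond the scatter is expected in this assay. The estimated change is small, a 1.1-fold higher number from compound 1 to compound 3 (0.04 log units; within the scatter). For compound 3 the estimated value is 4500 nM, with an expected range from 2000 nM to 10000 nM.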

Compound 3, half-maximal inhibitory concentration: 1770 nM
The estimate for compound 3 lay 2.5-fold (0.41 log units) above the measured number; the measured number lies below the stated range.
By their numbers in this assay, from the lowest: compound 3; then compounds 1 and 2 (each within the scatter of the next).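

Replacing chloro with trifluoromethyl, the change from 4-chlorophenyl to 4-(trifluoromethyl)phenyl, gives a 2.3-fold lower number from compound 1 to compound 3 (0.36 log units; beyond the scatter) in this assay. This shows that the group at this position affects the result on the core of compound 1, and that trifluoromethyl, with four heavy atoms against one for chloro, is tolerated there. Nothing available explains why the number fell. As far as these compounds go, whether an amine or a carboxylic acid at the same position would lower the number further remains open. So does whether the same swap would have a similar effect on a different core.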